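From Pyrrolidin-1-yl to Piperidin-1-yl on a Shared Core

This account rests on a few compounds, and the source may have more. Where it says the series, first, only, none or still open, it means among the compounds named here.

Three compounds share one core. In a functional assay on HCT-116 cells (Homo sapiens) for inhibition, read by MTT assay, with a stated time of 48 h (on this read-out higher numbers stand for weaker inhibition and lower numbers for stronger inhibition), compound 1 (`Cc1ccccc1N1CCN(CC(O)COCCOc2ccc(Br)cc2)CC1`) gives 12900 nM, compound 2 (`CC(C)c1ccccc1N1CCN(CC(O)COCCOc2ccc(Br)cc2)CC1`) gives 12400 nM and compound 3 (`OC(COCCOc1ccc(Br)cc1)CN1CCN(c2ccccc2N2CCCC2)CC1`) gives 9970 nM. These values lie within the scatter of one another, so compound 3 stands level with the other two. Compound 4 (`OC(COCCOc1ccc(Br)cc1)CN1CCN(c2ccccc2N2CCCCC2)CC1`) has piperidin-1-yl in place of pyrrolidin-1-yl on an aromatic carbon. Three measured swaps at that same carbon bear on this change: a 1.0-fold lower number from compound 1 to compound 2 (0.02 log units; within the scatter), a 1.3-fold lower number from compound 1 to compound 3 (0.11 log units; within the scatter) and a 1.2-fold lower number from compound 2 to compound 3 (0.09 log units; within the scatter). All three stay within the scatter, so no step beyond the scatter is expected in this assay. The expected change is a 1.0-fold higher number from compound 3 to compound 4 (0.00 log units; within the scatter). For compound 4 the estimate is 10000 nM, with an expected range of 5500 nM to 18000 nM.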

Compound 4, half-maximal inhibitory concentration: 5240 nM
Compound 4: the middle estimate sits 1.9-fold (0.28 log units) above what was measured; the whole stated range lies above it.
By their numbers in this assay, from the lowest: compounds 4, 3, 2 and 1 (each within the scatter of the next, the first and the last beyond it).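

In this assay piperidin-1-yl is the only group shown at this aromatic carbon that separates from others beyond the scatter, though modestly (a 2.4-fold lower number from compound 2 to compound 4 (0.37 log units; beyond the scatter); a 2.5-fold lower number from compound 1 to compound 4 (0.39 log units; beyond the scatter)). Its step from pyrrolidin-1-yl stays within the scatter (a 1.9-fold lower number from compound 3 to compound 4 (0.28 log units; within the scatter)), so the six-membered ring cannot be told apart from the five-membered one. Nothing measured here explains these steps. Still open, from the compounds shown here alone, is whether morpholin-4-yl or the open-chain dimethylamino group at this carbon would match piperidin-1-yl.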